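The source may hold more compounds than are shown below. What is called first, only, known or untested is meant among the compounds shown, and "the series" means these compounds.

Measured compounds:
compound 1 `O=C(O)Cc1ccccc1-c1cccc(NC(=O)OCc2ccccc2)c1`: 3.06
compound 2 `O=C1CN(Cc2ccc(-c3ccc(C4(C(=O)O)CC4)cc3)cc2)C(=O)N1c1ccccc1`: 1.5
compound 3 `O=C(O)Cc1ccc(-c2ccc(N(C(=O)OCc3ccccc3)C3CCCCC3)cc2)cc1`: 4.92

These numbers come from a physicochemical assay for lipophilicity, read by HPLC, at pH 7.4; a lower number here means a more polar compound, a higher number a more lipophilic compound. Among the three measured compounds, compound 3 stands highest: its value lies above that of compound 1 by a gap beyond the scatter, and further still above that of compound 2. Compound 4 `O=C(O)Cc1ccc(-c2ccc(N(C(=O)OCc3ccccc3)C3CCOCC3)cc2)cc1` differs from compound 3 in a single place: oxan-4-yl in place of cyclohexyl on an amide-type nitrogen. Among the measured compounds shown here, no measured pair in this set shows that exact change, so the size of the step rests on expectation alone. A downward step beyond the scatter is expected, estimated at a number 1.12 log units lower from compound 3 to compound 4 (beyond the scatter) in this assay. Compound 4 is accordingly expected to give 3.8 in this assay, with a likely range from 3.2 to 4.4.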

Compound 4, distribution coefficient: 3.13
For compound 4 the middle estimate is 0.67 log units above the measured one; measured number below the stated range.
By their numbers in this assay, from the lowest: compound 2; then compounds 1 and 4 (each within the scatter of the next); then compound 3.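

On the amide-type nitrogen, oxan-4-yl in place of cyclohexyl gives, in this assay, a number 1.79 log units lower from compound 3 to compound 4 (beyond the scatter). This is the only pair shown that differs in one place, and it shows that this position responds strongly to replacing one ring carbon with oxygen, even though both groups have the same number of heavy atoms and no net charge. Nothing available here explains the size of the step. On these data alone, whether a piperidin-4-yl ring, with nitrogen in that ring position, or a smaller cyclopentyl ring would give a similar step remains open. So does whether this exchange would have the same effect on another core.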